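The compounds below may be only part of what the source reports. "The series", "measured", "known", "first", "only" and "open" are said of these compounds alone.

Measured so far in an ADME assay on microsomes from liver (Homo sapiens) for metabolic stability, using NADPH, with a stated time of 30 min, in the presence of a further agent that is not named here; a lower number here means that less of the compound is left, a higher number that more of the compound is left:
compound 1 `O=S(=O)(c1ccc(Cl)cc1)N1CCc2n[nH]cc2C1CO`: 84%
compound 2 `O=S(=O)(c1ccc(Cl)cc1)N1CCc2n[nH]cc2C1c1nccs1`: 57%
compound 3 `O=S(=O)(c1ccc(Cl)cc1)N1Cc2c[nH]nc2CC1c1cncnc1`: 67%

Compound 3 stands second highest of the three numbers. Its nearest neighbour is compound 2, whose value lies within the scatter of that of compound 3, so no order between the two can be claimed. Compound 1 lies beyond the scatter above compound 3.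

Compound 4 `O=S(=O)(c1ccc(Cl)cc1)N1Cc2c[nH]nc2CC1c1cccc(F)c1` is not yet measured. Relative to compound 3 the change is 3-fluorophenyl in place of pyrimidin-5-yl on a saturated ring carbon. Among the compounds with values here, the only measured step, a number 27 percentage points lower from compound 1 to compound 2 (beyond the scatter), puts 1,3-thiazol-2-yl in place of hydroxymethyl on a saturated ring carbon; it does not bear directly on swapping one six-membered aromatic ring for another. Compounds 2 and 3, each carrying such a ring at that position, differ only within the scatter. Within the data shown here, no measured step covers a ring-for-ring exchange of this kind. The expectation for compound 4 is therefore a small to modest decrease, a number 7 percentage points lower from compound 3 to compound 4 (within the scatter), not confidently beyond the scatter. Compound 4 is estimated at 60%, within a range from 38% to 80%.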

Compound 4, percent of the compound remaining: 14%
Compound 4: the middle estimate sits 46 percentage points above what was measured, outside the stated range (below it).
By their numbers in this assay, from the lowest: compound 4; then compounds 2 and 3 (each within the scatter of the next); then compound 1.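

Exchanging pyrimidin-5-yl for 3-fluorophenyl gives a number 53 percentage points lower from compound 3 to compound 4 (beyond the scatter) in this assay and shows that the outcome depends strongly on which six-membered aromatic ring sits on the saturated ring carbon next to the ring nitrogen. Within the data shown here, the two rings cannot be treated as interchangeable at this position, as this is the first ring-for-ring exchange with a measured step. No measurement available here explains the step.

As far as these compounds go, the change removes the ring nitrogens and adds fluorine in one move, so the share of each in the step remains open. An unsubstituted phenyl or a pyridin-3-yl ring at the same position would separate the two, and an amine-bearing phenyl ring would test whether a nitrogen outside the ring has any comparable link to the read-out.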